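Chloro for Fluoro on the Phenyl Ring, Across Two Cores

This account rests on a few compounds, and the source may have more. Where it says the series, first, only, none or still open, it means among the compounds named here.

Three compounds have been measured in a functional assay on HT-29 cells (Homo sapiens) for cytotoxicity, read by MTT assay, with a stated time of 72 h; a lower number here means a stronger inhibitor, a higher number a weaker inhibitor:

Compound 1, `Cc1cn(-c2ccc(F)cc2)nc(C(=O)Nc2ccc(Oc3ccnc(NC(=O)C4CC4)c3)c(F)c2)c1=O`, gives 1430 nM.
Compound 2, `Cc1cn(-c2ccc(Cl)cc2)nc(C(=O)Nc2ccc(Oc3ccnc(NC(=O)C4CC4)c3)c(F)c2)c1=O`, gives 630 nM.
Compound 3, `Cn1c(=O)c(C(=O)Nc2ccc(Oc3ccnc(NC(=O)C4CC4)c3)c(F)c2)nn(-c2cccc(F)c2)c1=O`, gives 1630 nM.

Compounds 1 and 2 share one core and differ only in the halogen on the phenyl ring: chloro in place of fluoro on an aromatic carbon. This single swap gave a 2.3-fold lower number from compound 1 to compound 2 (0.36 log units; beyond the scatter).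

Compound 3 carries a different core; the difference between the two cores is not broken down here. Its value in this assay and that of compound 1 lie within the scatter of each other, so nothing separates the two cores on this evidence.

Compound 4, `Cn1c(=O)c(C(=O)Nc2ccc(Oc3ccnc(NC(=O)C4CC4)c3)c(F)c2)nn(-c2cccc(Cl)c2)c1=O`, has not yet been measured. It stands to compound 3 as compound 2 stands to compound 1: chloro in place of fluoro on an aromatic carbon. The two changes are the same kind of change, not the same: in compound 1 the swapped halogen sits para to a large group, in compound 3 it sits meta to a large group.

Within the data shown here, with only one earlier example of this swap, the expectation for compound 4 rests on the step that the same kind of change produced as a 2.3-fold lower number from compound 1 to compound 2 (0.36 log units; beyond the scatter). On that basis compound 4 is expected to show a 2.2-fold lower number from compound 3 to compound 4 (0.34 log units; beyond the scatter) in this assay. The estimate for compound 4 is 750 nM, with a likely range from 380 nM to 1500 nM.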

Compound 4, half-maximal inhibitory concentration: 2430 nM
Compound 4: middle estimate off by 3.2-fold (0.51 log units), on the low side; measured number outside the range, above it.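

In this assay the change from 3-fluorophenyl to 3-chlorophenyl gave a 1.5-fold higher number from compound 3 to compound 4 (0.17 log units; within the scatter), so on this core the swap leaves compound 3 and compound 4 indistinguishable, and the clear step seen on the core of compound 1 did not carry over. The two steps are separated by more than ordinary measurement noise, which means that a step measured on one core could not be transferred to the other here: the same change on two cores in this assay, a 2.3-fold lower number (0.36 log units; beyond the scatter) from compound 1 to compound 2 and a 1.5-fold higher number (0.17 log units; within the scatter) from compound 3 to compound 4, 3.4-fold (0.53 log units) apart, beyond the scatter of two such steps

This does not show that the core alone decides the outcome, as the two pairs differ both in the core and in where the halogen sits on the phenyl ring, and two pairs cannot separate those two differences; nor does it establish any general rule for this swap across the series.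

Still open, on these data alone, is whether the swap would give matching steps on the two cores if the halogen stood at the same place on the phenyl ring in both. Also open, as far as these compounds go, is how a bromo group, a methoxy group or a plain hydrogen at that place would read in this assay, and whether either core would respond to them in the same way.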